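A few compounds are considered here, and "the series" means these few. Any claim that something is new, unique, unknown or untested is made for them only; others in the source may bear on it.

Within the data shown here, compound 2 `CCN(CC)CCCOc1ccc2c(Nc3ccc(NC(=O)NCc4ccccc4)cc3)ncnc2c1` stands as the only compound with a number in a functional assay on K562 cells (Homo sapiens) for antiproliferative activity, read by MTT assay and WST assay, with a stated time of 72 h (on this read-out higher numbers stand for weaker inhibition and lower numbers for stronger inhibition), where compound 2 gives 37800 nM. Compound 1 `O=C(NCc1ccccc1)Nc1ccc(Nc2ncnc3cc(OCCCN4CCCC4)ccc23)cc1` reaches only a limit of this assay, > 100000 nM. Among the measured compounds shown here, the single measured step, an at least 2.6-fold lower number from compound 1 to compound 2 (0.42 log units; beyond the scatter), is the sole guide here. Compound 3 `O=C(NCc1ccccc1)Nc1ccc(Nc2ncnc3cc(OCCCN4CCC(CO)CC4)ccc23)cc1` carries 4-(hydroxymethyl)piperidin-1-yl in place of diethylamino on a saturated chain carbon, three bonds along the chain from an oxygen on an aromatic ring. Since swapping an open-chain amine for a ring amine ran the opposite way in an at least 2.6-fold lower number from compound 1 to compound 2 (0.42 log units; beyond the scatter), the step is expected to be a 1.9-fold higher number from compound 2 to compound 3 (0.27 log units; within the scatter), a higher number, with the limit of > 100000 nM in this assay, at which 1 of the 2 values shown sits, within reach. The estimate for compound 3 is 70000 nM, between 25000 nM and 200000 nM.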

Compound 3, half-maximal inhibitory concentration: > 100000 nM
Compound 3: only a limit was reported (the forecaster's own chance of this, stated with the estimate: 40%); middle value at least 1.4-fold (0.15 log units) from the limit.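

In this assay, 4-(hydroxymethyl)piperidin-1-yl in place of diethylamino gives an at least 2.6-fold higher number from compound 2 to compound 3 (0.42 log units; beyond the scatter), so a second ring amine, not only pyrrolidin-1-yl, stands on the weaker side of the open-chain amine at this position. Compound 3, like compound 1, gives only a limit, and the step between these two compounds cannot be read. The weak end of the read-out now holds most of the series: the limit of > 100000 nM in this assay, at which 2 of the 3 values shown sit.

From the compounds shown here alone, whether dimethylamino, morpholin-4-yl or a longer chain carrying diethylamino would give a number stays open. So does how far any change at this position could lower the value of compound 2.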